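Three Limits on Vero Cells and One Fresh Substituent

The source may hold more compounds than are shown below. What is called first, only, known or untested is meant among the compounds shown, and "the series" means these compounds.

Compound 1 `COc1cccc(NC(=O)c2nnn(Cc3ccc(-n4cccn4)cc3)c2N)c1` gives > 50100 nM in a toxicity assay on Vero cells (Chlorocebus sabaeus) for inhibition; on this read-out higher numbers stand for an effect only at larger amounts of compound and lower numbers for an effect already at smaller amounts.
Compound 2 `COc1cccc(NC(=O)c2nnn(Cc3ccccc3)c2N)c1` gives > 50100 nM in this assay.
Compound 3 `COc1cccc(NC(=O)c2nnn(CC3CCN(C(C)=O)CC3)c2N)c1` gives > 50100 nM in this assay.

Each of these three values is a limit of the assay and not a measured number. Compound 1 therefore stands only at a limit in this assay, with no number of its own. The same holds for the other two compounds, which is summed up by the limit of > 50100 nM in this assay, at which 3 of the 3 values shown sit. The two measured steps cannot be sized: a step that the two limits leave unreadable from compound 1 to compound 2, and a step that the two limits leave unreadable from compound 2 to compound 3.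

Compound 4 `COc1cccc(NC(=O)c2nnn(Cc3ccc([S+](C)[O-])cc3)c2N)c1` is not yet measured. It differs from compound 1 as follows: a group of 3 heavy atoms (1 carbon, 1 oxygen, 1 sulfur; no ring) in place of a group of 5 heavy atoms (3 carbon, 2 nitrogen; one five-membered aromatic ring with 2 hetero atoms), on an aromatic carbon

Both measured steps bear on the question only by showing that changes at this ring and at the chain left every value at the limit, as the limit of > 50100 nM in this assay, at which 3 of the 3 values shown sit, records. For compound 4 the expectation is therefore a value again at or beyond that limit, estimated as 60000 nM with a range from 30000 nM to 150000 nM. The step that the limit leaves unreadable from compound 1 to compound 4 is thus expected to show no effect readable beyond the scatter.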

Compound 4, half-maximal effective concentration in the Vero assay: > 50100 nM
Compound 4: only a limit was reported (the forecaster's own chance of this, stated with the estimate: 85%); the middle value is on the limit's open side.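

Compound 4 also gives only a limit of the assay, so in the Vero assay no new step can be read among compound 1, compound 2, compound 3 and compound 4: the limit of > 50100 nM in the Vero assay, at which 4 of the 4 values shown sit.

In a physicochemical assay for lipophilicity, read by HPLC, measured as chromatographic lipophilicity, at pH 7.4 (on this read-out higher numbers stand for higher lipophilicity and lower numbers for lower lipophilicity), compound 1 gives 2.4 and compound 4 gives 1.3 here. The amount at which any of these compounds would have an effect in the Vero assay stays open.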